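Second bromo on the pyrrole: a small expected shift

The source may hold more compounds than are shown below. What is called first, only, known or untested is meant among the compounds shown, and "the series" means these compounds.

Two compounds of this series have been measured in an assay with sodium channel protein type 3 subunit alpha (Homo sapiens) as the target, read by patch clamp; on this read-out lower numbers stand for stronger inhibition and higher numbers for weaker inhibition:

Compound 1 `Nc1nc2c(s1)CC(CNC(=O)c1ccc[nH]1)CC2`: 28000 nM
Compound 2 `Nc1nc2c(s1)CC(CNC(=O)c1cc(Br)c[nH]1)CC2`: 20000 nM

Within the data shown here, compound 2 and compound 1 lie within the scatter of each other, as the only step between them, a 1.4-fold lower number from compound 1 to compound 2 (0.15 log units; within the scatter), shows. The next compound, compound 3 `Nc1nc2c(s1)CC(CNC(=O)c1cc(Br)c(Br)[nH]1)CC2`, has not been measured. It differs from compound 2 by bromo in place of hydrogen on an aromatic carbon, that is, 4-bromo-1H-pyrrol-2-yl becomes 4,5-dibromo-1H-pyrrol-2-yl. Among the measured compounds shown here, the only measured step that bears on this change is the first bromination, a 1.4-fold lower number from compound 1 to compound 2 (0.15 log units; within the scatter), which stayed within the scatter. On that basis the second bromo is expected to bring a 1.3-fold lower number from compound 2 to compound 3 (0.12 log units; within the scatter) in this assay, with no step beyond the scatter foreseen. Compound 3 is therefore estimated at 15000 nM, between 6000 nM and 40000 nM.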

Compound 3, half-maximal inhibitory concentration: 18000 nM
Estimate against measurement, compound 3: 1.2-fold (0.08 log units) below; the measured number falls inside the stated range.
By their numbers in this assay, from the lowest: compounds 3, 2 and 1 (each within the scatter of the next).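

In this assay, among these compounds, bromo on the aromatic carbon next to the ring nitrogen brings a 1.1-fold lower number from compound 2 to compound 3 (0.05 log units; within the scatter), so this position, unsubstituted in the earlier compounds, also gives no step beyond the scatter. Read as one change, 4,5-dibromo-1H-pyrrol-2-yl in place of 1H-pyrrol-2-yl brings a 1.6-fold lower number from compound 1 to compound 3 (0.19 log units; within the scatter), so even the two bromo groups together do not separate compound 3 from compound 1 on this read-out. Nothing available explains this result.

The compounds shown leave open whether a different group at this position, such as chloro, methyl or a carboxylic acid, would give a step beyond the scatter. They also leave open whether a change elsewhere, such as an acetamide in place of the amine on the shared core, would do so.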